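This account rests on a few compounds, and the source may have more. Where it says the series, first, only, none or still open, it means among the compounds named here.

Compound 1 `O=S(=O)(/C=C/c1ccccn1)c1cccc(F)c1` gives 1680 nM in an assay on U2OS cells for activation of nuclear factor erythroid 2-related factor 2 (Homo sapiens), read by beta-arrestin recruitment, with a stated time of 6 h; on this read-out lower numbers stand for an effect already at smaller amounts and higher numbers for an effect only at larger amounts of compound. Compound 2 `O=S(=O)(/C=C/c1ccccn1)c1cccc(Cl)c1` gives 1430 nM in this assay. The two differ only in that (chloro in place of fluoro on an aromatic carbon), and this change made a 1.2-fold lower number from compound 1 to compound 2 (0.07 log units; within the scatter). Compound 3 `O=S(=O)(/C=C/c1ccncc1)c1ccccc1F` gives 760 nM in this assay; compound 3 and compound 1 have the same atoms joined differently, and the difference between the two cores is not broken down here. Compound 4 `O=S(=O)(/C=C/c1ccncc1)c1ccccc1Cl` has not yet been measured. It differs from compound 3 in that (chloro in place of fluoro on an aromatic carbon). The place is not identical: in compound 1 the fluoro sits meta to a large group, in compound 3 ortho to a large group, so this is the same kind of change, not the same. Because a 1.2-fold lower number from compound 1 to compound 2 (0.07 log units; within the scatter) was small, the expected step is a 1.2-fold lower number from compound 3 to compound 4 (0.07 log units; within the scatter). Compound 4 is therefore estimated at 650 nM, expected between 300 nM and 1400 nM.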

Compound 4, half-maximal effective concentration: 781 nM
Compound 4: middle estimate off by 1.2-fold (0.08 log units), on the low side; low and high end bracket the measured number.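

On the core of compound 3, chloro in place of fluoro gives a 1.0-fold higher number from compound 3 to compound 4 (0.01 log units; within the scatter) in this assay. Set beside the earlier step, the same swap behaves alike on both cores: the same change on two cores in this assay, a 1.2-fold lower number (0.07 log units; within the scatter) from compound 1 to compound 2 and a 1.0-fold higher number (0.01 log units; within the scatter) from compound 3 to compound 4, 1.2-fold (0.08 log units) apart, within the scatter of two such steps. This shows that the swap carried from one core to the other as a change too small to tell from scatter, but it does not show that this would hold on a further core, or for a swap that has a larger effect.

The compounds shown carry only fluoro or chloro on the aromatic ring of carbon only. From the compounds shown here alone, what a methoxy group, an amine or a carboxylic acid would do in that place stays open.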